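Adding a Methyl to the Amide Chain of Compound 3

This account rests on a few compounds, and the source may have more. Where it says the series, first, only, none or still open, it means among the compounds named here.

Of the compounds shown here, three sharing an anilide core have been tested in an assay on isolated protein for binding affinity to melatonin receptor type 1A (Homo sapiens); on this read-out lower numbers stand for stronger inhibition and higher numbers for weaker inhibition. Compound 1, `CCCC(=O)Nc1ccc(Oc2ccc(OC)cc2)cc1`, gives only a limit in this assay, > 500 nM, so no number is known for it; that limit is the limit of > 500 nM in this assay, at which 1 of the 3 values shown sits. Compound 2, `COc1cccc(Oc2ccc(NC(=O)C3CC3)cc2)c1`, gives 99 nM in this assay. Compound 3, `CCC(=O)Nc1ccc(Nc2cccc(OC)c2)cc1`, gives 61 nM in this assay, and this number and the number of compound 2 lie within the usual scatter of each other, so neither can be called the stronger binder.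

Compound 4, `COc1cccc(Nc2ccc(NC(=O)C(C)C)cc2)c1`, differs from compound 3 in one place: methyl in place of hydrogen on a saturated chain carbon bound to a carbonyl carbon and a saturated chain carbon. Among the measured compounds no pair differs in a single place, so there is no measured step to draw on. The expectation for the step from compound 3 to compound 4 in this assay, a 1.3-fold higher number from compound 3 to compound 4 (0.12 log units; within the scatter), is a change that stays within the scatter, with no clear direction. Compound 4 is therefore estimated at 80 nM, with a likely range from 30 nM to 250 nM.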

Compound 4, inhibition constant: > 500 nM
Compound 4 gave a limit, no number; the forecaster's own chance of this, stated with the estimate: 5%; at least 6.2-fold (0.79 log units) between middle value and limit.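

Within the data shown here, the earlier compounds offered no pair differing in a single place, so this pair gives the only direct reading of a change on the amide chain. In this assay, a methyl in place of hydrogen on the saturated chain carbon bound to the carbonyl carbon, which turns ethyl into isopropyl, gives an at least 8.1-fold higher number from compound 3 to compound 4 (0.91 log units; beyond the scatter), so binding at this position is sensitive to even this small addition. The value of compound 4 is a limit, so the step has a known minimum but no known maximum: the limit of > 500 nM in this assay, at which 2 of the 4 values shown sit.

Open, on these data alone, is whether a tert-butyl group on the same amide, or a smaller acetyl group, would follow this trend. Also open, as far as these compounds go, is whether a hydroxyl group on that same carbon would be tolerated where the methyl is not.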